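This account rests on a few compounds, and the source may have more. Where it says the series, first, only, none or still open, it means among the compounds named here.

Among the measured compounds shown here, compound 2 `CC(C(=O)NCc1ccc(C(F)(F)F)nc1N(C)C)c1ccc(NS(C)(=O)=O)c(F)c1` gives 2390 nM in a functional assay on CHO-K1 cells for antagonist activity at transient receptor potential cation channel subfamily V member 1 (Homo sapiens), read by FLIPR (a higher number here means a weaker inhibitor, a lower number a stronger inhibitor), the higher of the two numbers so far; compound 1 `CC1CCC(Nc2nc(C(F)(F)F)ccc2CNC(=O)C(C)c2ccc(NS(C)(=O)=O)c(F)c2)CC1` gives 1130 nM. For the measured compounds named here, the single measured step, a 2.1-fold higher number from compound 1 to compound 2 (0.33 log units; beyond the scatter), is the only comparison that bears on compound 3 `CC(=O)OC1CCN(c2nc(C(F)(F)F)ccc2CNC(=O)C(C)c2ccc(NS(C)(=O)=O)c(F)c2)CC1`. Compound 3 carries 4-acetoxypiperidin-1-yl in place of dimethylamino on an aromatic carbon. That change brings back a six-membered non-aromatic ring at the same carbon where compound 1 had its (4-methylcyclohexyl)amino group, so a partial return toward compound 1 seems plausible, though not assured. The step to compound 3 is therefore expected to be a modest lowering, a 1.7-fold lower number from compound 2 to compound 3 (0.23 log units; within the scatter). In this assay compound 3 is estimated at 1400 nM, within 600 nM to 3500 nM.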

Compound 3, half-maximal inhibitory concentration: 139 nM
Estimate against measurement, compound 3: 10-fold (1.00 log units) above, and the stated range ends above it.
By their numbers in this assay, from the lowest: compound 3; then compound 1; then compound 2.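

On the aromatic carbon next to the ring nitrogen, 4-acetoxypiperidin-1-yl gives a 17-fold lower number from compound 2 to compound 3 (1.24 log units; beyond the scatter), and against (4-methylcyclohexyl)amino it gives an 8.1-fold lower number from compound 1 to compound 3 (0.91 log units; beyond the scatter). This position therefore moves the number much further than the first step suggested, and a six-membered non-aromatic ring does not by itself set the level, as both compound 1 and compound 3 carry one. Nothing available explains either step. The compounds shown leave open whether the acetoxy group or the ring attached through its nitrogen carries the gain. Plain piperidin-1-yl and 4-hydroxypiperidin-1-yl would separate the two.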